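The compounds below may be only part of what the source reports. "The series", "measured", "known", "first", "only" and "open" are said of these compounds alone.

The two measured compounds share one core and differ only in where the methyl sits on the phenyl ring. Compound 1 `Cc1cccc(-c2nnc(CSc3nnc(/N=C/c4ccccc4O)s3)o2)c1` gives 11600 nM in a functional assay on MCF7 cells (Homo sapiens) for inhibition, read by CCK-8 assay; a lower number here means a stronger inhibitor, a higher number a weaker inhibitor. Compound 2 `Cc1ccc(-c2nnc(CSc3nnc(/N=C/c4ccccc4O)s3)o2)cc1` gives 8750 nM in this assay, and the step of a 1.3-fold lower number from compound 1 to compound 2 (0.12 log units; within the scatter) shows that the two numbers lie within the scatter of each other, so compound 2 cannot be placed above or below compound 1 on this evidence.

Compound 3 `COc1ccc(-c2nnc(CSc3nnc(/N=C/c4ccccc4O)s3)o2)cc1` is the next compound in this line. Its change from compound 2 is methoxy in place of methyl on an aromatic carbon. For the measured compounds named here, no measured step concerns a methoxy group or any exchange of one group for another at the same position; the only measured step, from compound 1 to compound 2, moves a methyl from one ring carbon to another and itself stays within the scatter. There is therefore nothing in the data to support a step beyond the scatter in this assay in either direction.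

Compound 3 is accordingly expected to give about 8500 nM in this assay, with a range from 3000 nM to 25000 nM. The expected step of a 1.0-fold lower number from compound 2 to compound 3 (0.01 log units; within the scatter) is an estimate, not a measurement.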

Compound 3, half-maximal inhibitory concentration: 4560 nM
Beside the measured number, compound 3's estimate is 1.9-fold (0.27 log units) above it; the measured number falls inside the stated range.
By their numbers in this assay, from the lowest: compounds 3, 2 and 1 (each within the scatter of the next, the first and the last beyond it).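

At the ring carbon para to a large group, methoxy in place of methyl gives a 1.9-fold lower number from compound 2 to compound 3 (0.28 log units; within the scatter) in this assay and so cannot be told apart from no change at this position. For the compounds shown here, compound 3 does, however, give the first pair that separates, with a 2.5-fold lower number from compound 1 to compound 3 (0.41 log units; beyond the scatter) as a modest step in this assay, although that step changes both the group and its place on the ring and cannot be credited to either change alone. Nothing available here accounts for these numbers.

Going by these compounds, it remains open whether a halogen such as chlorine, an amine or a carboxylic acid on this same carbon would move the number beyond the scatter from compound 2. Also open, on these data alone, are whether a longer chain such as ethoxy would go further than methoxy, and how methoxy would behave on the ring carbon that holds the methyl in compound 1, which would separate the effect of the group from that of its place.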